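This account rests on a few compounds, and the source may have more. Where it says the series, first, only, none or still open, it means among the compounds named here.

Compound 1 `CC(C)=CCOc1c(C)c(C)c2c(c1C)CCC(C)(COc1ccc(/C=C3\SC(=O)NC3=O)cc1F)O2`: 95%
Compound 2 `C=CCOc1c(C)c(C)c2c(c1C)CCC(C)(COc1ccc(/C=C3\SC(=O)NC3=O)cc1OCC)O2`: 107%

In a functional assay on MCF7 cells (Homo sapiens), tested at 2.5 uM (on this read-out higher numbers stand for a weaker effect at the one concentration tested and lower numbers for a stronger effect), compound 2 gives 107%, the higher of the two numbers, and compound 1 gives 95%, a number lower by more than the usual scatter. Compound 3 `CCOc1cc(/C=C2\SC(=O)NC2=O)ccc1OCC1(C)CCc2c(C)c(OCC=C(C)C)c(C)c(C)c2O1` differs from compound 2 in one place: 2-methylprop-1-en-1-yl in place of vinyl on a saturated chain carbon bound to an oxygen on an aromatic ring. For the measured compounds named here, no measured pair shows this change on its own, so the expectation rests on compound 2 alone. The change is expected to bring no step beyond the scatter, a number 7 percentage points lower from compound 2 to compound 3 (within the scatter). For compound 3 in this assay the estimate is 100%, within a range from 85% to 115%.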

Compound 3, a percentage reported as activity, at one concentration (the size of the read-out at that concentration, not a potency): 107%
Beside the measured number, compound 3's estimate is 7 percentage points below it, and the stated range covers the measured number.
By their numbers in this assay, from the lowest: compound 1; then compounds 2 and 3 (each within the scatter of the next).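

In this assay, the larger 2-methylprop-1-en-1-yl group in place of vinyl on a saturated chain carbon bound to an oxygen on an aromatic ring gives no change at the digits printed from compound 2 to compound 3 (within the scatter). Ethoxy in place of fluoro on an aromatic carbon gives a number 12 percentage points higher from compound 1 to compound 3 (beyond the scatter), so the two compounds now differ at this aromatic carbon alone. No measurement available gives a reason for either step. On these data alone, whether an amine or a carboxylic acid on that aromatic carbon would shift the read-out remains open, as does the outcome of a longer chain on the oxygen.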